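A few compounds are considered here, and "the series" means these few. Any claim that something is new, unique, unknown or untested is made for them only; others in the source may bear on it.

Compound 2, `N#Cc1ccc(OCC(=O)O)c(C#Cc2ccccc2Cl)c1`, was tested in an assay on CHO cells for displacement of a labelled ligand from prostaglandin D2 receptor 2 (Homo sapiens), read by scintillation counting (on this read-out higher numbers stand for weaker inhibition and lower numbers for stronger inhibition), and gives 24 nM. Among the three compounds measured, it holds the second highest number: compound 3, `Cc1ccc(S(=O)(=O)CCO)cc1C#Cc1cc(Cl)ccc1OCC(=O)O`, gives 19 nM, which sits within the usual scatter of compound 2, while compound 1, `O=C(O)COc1ccccc1C#Cc1ccccc1Cl`, gives 747 nM, far above it.

Compound 4, `O=C(O)COc1ccc(Cl)cc1C#Cc1ccccc1Cl`, has not yet been measured. It differs from compound 2 in one place: chloro in place of cyano on an aromatic carbon.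

Among the compounds with values here, only one measured step touches this position. It runs from compound 1 to compound 2, a 31-fold lower number from compound 1 to compound 2 (1.49 log units; beyond the scatter), and shows that placing a cyano group where hydrogen had been is a large change in this assay. Within the data shown here, no measured pair shows a chloro group replacing a cyano group directly. Compound 3, which carries a chloro group at the same kind of position but a different group elsewhere, shows a number close to compound 2, which hints that a chloro group at this place is compatible with a low number.

Compound 4 is therefore expected to stay well below compound 1, with a step from compound 2 of a 2.5-fold higher number from compound 2 to compound 4 (0.40 log units; beyond the scatter), most likely a modest rise. The estimate for compound 4 is 60 nM, with a range from 15 nM to 250 nM.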

Compound 4, inhibition constant: 28 nM
The estimate for compound 4 lay 2.1-fold (0.33 log units) above the measured number, and the stated range covers the measured number.
By their numbers in this assay, from the lowest: compounds 3, 2 and 4 (each within the scatter of the next); then compound 1.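

In this assay, chloro can take the place of cyano on this aromatic carbon, para to the carboxymethoxy group, with no change that can be told from the scatter (a 1.2-fold higher number from compound 2 to compound 4 (0.07 log units; within the scatter)). Measured against the hydrogen of compound 1, chloro gives a large step (a 27-fold lower number from compound 1 to compound 4 (1.43 log units; beyond the scatter)), much like the one cyano gives (a 31-fold lower number from compound 1 to compound 2 (1.49 log units; beyond the scatter)), so among these compounds the large drop in the number does not depend on cyano, even though the two groups differ in heavy atoms, in hydrogen-bond acceptors and in the triple bond that only cyano carries. Nothing presented here accounts for this match between the two groups.

With only hydrogen, cyano and chloro shown on this carbon, it remains open whether a methyl group, a methoxy group, an amine or a carboxylic acid would also give a number close to those of compound 2 and compound 4. From the compounds shown here alone, it is also open whether chloro and cyano would still match if the 2-chlorophenyl end of the core carried a different group, as the changes in compound 3 lie in more than one place and give no clean comparison.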